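Trifluoromethyl in place of methyl at two placements

This account rests on a few compounds, and the source may have more. Where it says the series, first, only, none or still open, it means among the compounds named here.

Three compounds of the series have been run in an assay on isolated protein for inhibition of Amine oxidase [flavin-containing] A (Homo sapiens), read by Amplex Red, with a stated time of 15 min, tested at 100 uM; a higher number here means more inhibition at the concentration tested (going by the name of the read-out), a lower number less inhibition. Compound 1 `CC(=O)c1cccc(OCc2cccc(C)c2)c1` gives 31.1%, and compound 3 `CC(=O)c1cccc(OCc2cccc(C(F)(F)F)c2)c1` gives 46.7%. The change between them is trifluoromethyl in place of methyl on an aromatic carbon, and it produced a step of a number 15.6 percentage points higher from compound 1 to compound 3 (beyond the scatter). Compound 2 `CC(=O)c1cccc(OCc2ccc(C)cc2)c1` gives 23%; this number and that of compound 1 lie within the scatter of each other, whereas the gap from compound 2 to compound 3 is beyond it. How the core of compound 2 differs from the core of compound 1 is not broken down here. Compound 4 `CC(=O)c1cccc(OCc2ccc(C(F)(F)F)cc2)c1` has not yet been measured; it differs from compound 2 by trifluoromethyl in place of methyl on an aromatic carbon. In compound 3 the entering group sits meta to a large group, in compound 4 para to a large group, so the two changes are the same kind of change rather than the same change. For compound 4 the expected step is a number 13 percentage points higher from compound 2 to compound 4 (beyond the scatter) in this assay, resting on the earlier measured step of a number 15.6 percentage points higher from compound 1 to compound 3 (beyond the scatter) and tempered by the difference in placement. Compound 4 is estimated at 36% in this assay, with a likely range from 22% to 50%.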

Compound 4, a percentage reported as inhibition, at one concentration (the size of the read-out at that concentration, not a potency): 27.2%
For compound 4 the middle estimate is 8.8 percentage points above the measured one; the measured number falls inside the stated range.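

In this assay trifluoromethyl in place of methyl on an aromatic carbon gives a number 4.2 percentage points higher from compound 2 to compound 4 (within the scatter). So on the core of compound 2 the change cannot be told from the scatter, yet this step does not set the two cores apart, since it stands within the scatter of the earlier step: the same change on two cores in this assay, a number 15.6 percentage points higher (beyond the scatter) from compound 1 to compound 3 and a number 4.2 percentage points higher (within the scatter) from compound 2 to compound 4, 11.4 percentage points apart, within the scatter of two such steps. This leaves open whether the change carries from one core to the other: one step lies beyond the scatter and one within it, the pair is too small to show a consistent gain or a loss of it, and the effect of the core cannot be separated from that of the placement.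

The compounds shown carry only methyl or trifluoromethyl at the varied site, so whether a nitrile, a chlorine atom or an amine there would follow either step remains open. The read-out at one concentration also leaves the potency of all four compounds open.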